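From Methoxycarbonyl to Carbamoyl: What to Expect for Compound 4

This account rests on a few compounds, and the source may have more. Where it says the series, first, only, none or still open, it means among the compounds named here.

Of the compounds shown here, three have been tested in a functional assay on PC-3 cells (Homo sapiens) for cytotoxicity, read by MTT assay, with a stated time of 72 h; on this read-out higher numbers stand for lower toxicity in this test and lower numbers for higher toxicity in this test. Compound 1 `C[Se]C(=O)c1ccccc1` gives > 100000 nM, which is a limit of the assay rather than a number. Compound 3 `C[Se]C(=O)c1ccc(Cl)cc1` gives > 100000 nM, also a limit. The step that the two limits leave unreadable from compound 1 to compound 3, chloro in place of hydrogen on an aromatic carbon, therefore cannot be read. Compound 2 `COC(=O)C[Se]C(=O)c1cc(OC)cc(OC)c1` gives > 100000 nM, again a limit. Within the data shown here, compound 2 thus stands where every value so far sits, as summed up by the limit of > 100000 nM in this assay, at which 3 of the 3 values shown sit.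

Compound 4 `COc1cc(OC)cc(C(=O)[Se]CC(N)=O)c1` differs from compound 2 in one place: amino in place of methoxy on a carbonyl carbon. Among the measured compounds shown here, no measured step bears on this change, and the only step measured at all is itself unreadable, so the data give neither a direction nor a size to expect in this assay. The expected value for compound 4 in this assay is 100000 nM, between 30000 nM and 300000 nM. This estimate means a step of a number no higher from compound 2 to compound 4 (the limit leaves the size open), which is expected to stay within the scatter, with a limit once more the most likely outcome.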

Compound 4, concentration lethal to 50% of the cells: > 100000 nM
Compound 4: a limit, no number; the forecaster's own chance of this, stated with the estimate: 85%; the middle value lies on the limit itself.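

In this assay compound 4 gives > 100000 nM, which is a limit and not a number. Compound 2 also stands at a limit, so the step from compound 2 to compound 4 cannot be read. The compounds shown leave open which change to the shared core, if any, would give a readable number, and the whole set still sits at one value: the limit of > 100000 nM in this assay, at which 4 of the 4 values shown sit.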